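From phenyl to 4-bromophenyl in compound 3

The compounds below may be only part of what the source reports. "The series", "measured", "known", "first", "only" and "open" are said of these compounds alone.

Values in a functional assay on HepG2 cells (Homo sapiens) for cytotoxicity, read by MTT assay, with a stated time of 48 h; a higher number here means a weaker inhibitor, a lower number a stronger inhibitor:
Compound 1 `O=[N+]([O-])c1ccc2[nH]c(CSCc3nc4cc([N+](=O)[O-])ccc4[nH]3)nc2c1` gives 2250 nM here
Compound 2 `O=C(CSCc1nc2cc([N+](=O)[O-])ccc2[nH]1)c1ccccc1` gives 16100 nM here

Compound 2 has the higher of the two numbers at 16100 nM in this assay, and the gap to compound 1 lies beyond the usual scatter. Compound 3 `O=C(CSCc1nc2cc([N+](=O)[O-])ccc2[nH]1)c1ccc(Br)cc1` has not yet been measured. It differs from compound 2 in one place: bromo in place of hydrogen on an aromatic carbon (bromo in place of hydrogen on an aromatic carbon, so that phenyl becomes 4-bromophenyl). For the measured compounds named here, no measured pair here shows a change of this kind, so the expectation is loose. Going by the values given here, the only guide is that compound 1 at 2250 nM shows a lower number is reachable. A modest move toward a stronger inhibitor is expected, with the estimated step of a 2.0-fold lower number from compound 2 to compound 3 (0.30 log units; within the scatter) close to the edge of the scatter. For compound 3 the estimated value is 8000 nM (expected range 3000 nM to 20000 nM).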

Compound 3, half-maximal inhibitory concentration: 2010 nM
The estimate for compound 3 lay 4.0-fold (0.60 log units) above the measured number; measured number below the stated range.
By their numbers in this assay, from the lowest: compounds 3 and 1 (each within the scatter of the next); then compound 2.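

The phenyl ring of compound 2 turns out to be a place that responds in this assay: bromo on an aromatic carbon, para to a large group, gives an 8.0-fold lower number from compound 2 to compound 3 (0.90 log units; beyond the scatter) while the rest of the structure stays unchanged. For the compounds shown here, this is the first single-place step, and it shows that one added heavy atom is enough to bring compound 3 to 2010 nM in this assay. Nothing measured here accounts for the size of this step.

Going by these compounds, it remains open whether chloro, methyl or an amine on the same carbon would give a step of similar size, or whether bromo elsewhere on the ring would do so. Also open, on these data alone, is what a nitrile or an amine in place of the nitro group would do alongside the 4-bromophenyl.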